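The compounds below may be only part of what the source reports. "The series", "measured", "known", "first", "only" and "open" are said of these compounds alone.

Measured compounds in a functional assay on MKN-45 cells (Homo sapiens) for antiproliferative activity, read by MTT assay, with a stated time of 72 h; on this read-out lower numbers stand for stronger inhibition and higher numbers for weaker inhibition:
compound 1, `COCCOc1ccc2c(Oc3ccc(Nc4nccc5[nH]cc(-c6ccc(F)cc6)c(=O)c45)cc3F)ccnc2c1`: 5600 nM
compound 2, `COCCOc1cc2nccc(Oc3ccc(Nc4nccc5[nH]cc(-c6ccc(F)cc6)c(=O)c45)cc3F)c2cc1OC`: 3100 nM
compound 3, `O=c1c(-c2ccc(F)cc2)c[nH]c2ccnc(Nc3ccc(Oc4ccnc5cc(O)ccc45)c(F)c3)c12`: 5000 nM

All three compounds share the same core and differ only at the edge of the bicyclic part. Compound 3, which carries a free hydroxy there, gives a number in this assay that lies within the usual scatter of both companions: the measured step is a 1.1-fold lower number from compound 1 to compound 3 (0.05 log units; within the scatter), and the gap to compound 2 is also within the scatter. Among the measured compounds shown here, on these numbers no compound separates from the others.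

Compound 4, `COC(C)(C)COc1ccc2c(Oc3ccc(Nc4nccc5[nH]cc(-c6ccc(F)cc6)c(=O)c45)cc3F)ccnc2c1`, is compound 3 with 2-methoxy-2-methylpropyl in place of hydrogen on an oxygen on an aromatic ring. One measured step speaks to this change. Going from compound 1 to compound 3, a 2-methoxyethyl on that same oxygen was removed, and the result was a 1.1-fold lower number from compound 1 to compound 3 (0.05 log units; within the scatter), so the oxygen with or without a chain on it made no measurable difference. Placing a different chain, 2-methoxy-2-methylpropyl, on the oxygen of compound 3 is the reverse kind of move, and the expectation is therefore a step no larger than the scatter, in either direction. The expected step is no change at the digits printed from compound 3 to compound 4 (within the scatter). Compound 4 is accordingly estimated at 5000 nM, with a range from 2200 nM to 11000 nM.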

Compound 4, half-maximal inhibitory concentration: 5500 nM
Beside the measured number, compound 4's estimate is 1.1-fold (0.04 log units) below it, within the range that was stated.
By their numbers in this assay, from the lowest: compounds 2, 3, 4 and 1 (each within the scatter of the next).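

In this assay the 2-methoxy-2-methylpropyl chain on the oxygen on an aromatic ring gives a 1.1-fold higher number from compound 3 to compound 4 (0.04 log units; within the scatter) and so stays within the scatter; the hydroxy-to-2-methoxy-2-methylpropoxy change is thus a chain added to the free hydroxy of compound 3, where the earlier step showed only the 2-methoxyethyl chain taken away. The compounds also now allow two chains on this oxygen to be compared directly: 1-methoxy-1-methylethyl in place of methoxymethyl on the saturated chain carbon gives a 1.0-fold lower number from compound 1 to compound 4 (0.01 log units; within the scatter) and this too lies within the scatter, so across compounds 1, 3 and 4 neither the presence of a chain nor this change in its branching separates one compound from another. Nothing shown here offers a reason for this lack of separation.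

Going by these compounds, whether the same holds for a chain ending in an amine such as morpholine, or in a carboxylic acid, remains open, since every group on this oxygen so far is a hydroxy or a methoxy-ended chain. Also open, on these data alone, is whether a longer chain would stay within the scatter, and whether 2-methoxy-2-methylpropyl would behave alike alongside the additional methoxy of compound 2.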